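Toward a smaller carboxylic acid amide on the shared core

This account rests on a few compounds, and the source may have more. Where it says the series, first, only, none or still open, it means among the compounds named here.

Measured so far:
Compound 1 `O=C(NC1(C(=O)O)CCCCC1)c1cccc2cc(-c3ccc(Cl)cc3)oc12` gives 120 nM.
Compound 2 `CN(C(=O)c1cc(F)cc2cc(-c3ccc(Cl)cc3)oc12)C(C)(C)C(=O)O` gives 1970 nM.
Compound 3 `O=C(NC1(C(=O)O)Cc2ccccc2C1)c1cc(F)cc2cc(-c3ccc(Cl)cc3)oc12` gives 115 nM.

These values come from an assay on isolated protein for inhibition of endoplasmic reticulum aminopeptidase 1 (Homo sapiens), with stated times of 15 min and 20 min; a lower number here means a stronger inhibitor, a higher number a weaker inhibitor. Among the three, compound 2 has the highest number: its gap to compound 1 and to compound 3 lies beyond the usual scatter, so it is the weakest inhibitor of the set. Compounds 1 and 3 sit close to each other, and their values alone do not separate them.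

Compound 4 `O=C(NC1(C(=O)O)CC1)c1cc(F)cc2cc(-c3ccc(Cl)cc3)oc12` has not yet been measured in this assay. It differs from compound 2 in one place: (1-carboxycyclopropyl)amino in place of (1-carboxy-1-methylethyl)(methyl)amino on a carbonyl carbon. The two stronger compounds, compound 1 and compound 3, both carry an amine with a single hydrogen on the amide nitrogen and a ring on the carbon that bears the carboxylic acid, as compound 4 does; compound 2 lacks both of these features. On that basis the number for compound 4 is expected to fall by a step of a 9.0-fold lower number from compound 2 to compound 4 (0.95 log units; beyond the scatter), moving toward the values of compound 1 and compound 3 rather than staying near compound 2. The estimate for compound 4 is 220 nM, with a likely range from 60 nM to 800 nM.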

Compound 4, half-maximal inhibitory concentration: 1120 nM
For compound 4 the middle estimate is 5.1-fold (0.71 log units) below the measured one, and the stated range ends below it.
By their numbers in this assay, from the lowest: compounds 3 and 1 (each within the scatter of the next); then compounds 4 and 2 (each within the scatter of the next).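

In this assay, (1-carboxycyclopropyl)amino in place of (1-carboxy-1-methylethyl)(methyl)amino gives a 1.8-fold lower number from compound 2 to compound 4 (0.25 log units; within the scatter), so this change on the carbonyl carbon leaves the two compounds unseparated. The amide hydrogen and a ring on the carbon bearing the carboxylic acid are therefore not enough on their own: compound 4 has both and gives 1120 nM, whereas compound 3, which differs from it only in that ring, gives 115 nM. Nothing available on these compounds accounts for this result.

The step changes the amide hydrogen and the ring together, so the compounds shown do not separate their contributions, and a (1-carboxy-1-methylethyl)amino group would address that directly. Also open, as far as these compounds go, is how ring size acts at this place, which a (1-carboxycyclobutyl)amino group on the same core would test.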